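Chloro to trifluoromethyl on the urea aryl of compound 1

The source may report more compounds than this note shows. Statements on the series, on what has been measured and on what is new or still open speak of the compounds shown alone.

Compound 1, `O=C(Nc1cccc(-n2cc(-c3ccncc3)c(-c3ccc(Cl)c(O)c3)n2)c1)Nc1ccc(Cl)c(Cl)c1`, is the starting point of this step. In a functional assay on HOP-92 cells (Homo sapiens) for inhibition, read by sulforhodamine B assay, with a stated time of 48 h (a higher number here means a weaker inhibitor of growth, a lower number a stronger inhibitor of growth), compound 1 gives 1910 nM, the lowest of the three numbers at hand, although the two others stand within the usual scatter of it. Compound 2, `COc1cc(-c2nn(-c3cccc(NC(=O)c4ccc(Cl)c(C(F)(F)F)c4)c3)cc2-c2ccncc2)ccc1Cl`, gives 3230 nM in this assay, and compound 3, `COc1cc(-c2nn(-c3cccc(NC(=O)c4cccc(C(F)(F)F)c4)c3)cc2-c2ccncc2)ccc1Cl`, gives 3120 nM.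

Compound 4, `O=C(Nc1cccc(-n2cc(-c3ccncc3)c(-c3ccc(Cl)c(O)c3)n2)c1)Nc1ccc(Cl)c(C(F)(F)F)c1`, is not yet measured. It differs from compound 1 in a single place: trifluoromethyl in place of chloro on an aromatic carbon.

For the measured compounds named here, only one measured step within this set concerns a substituent on the aryl ring attached to the amide or urea nitrogen: a 1.0-fold lower number from compound 2 to compound 3 (0.02 log units; within the scatter). That change removes a chloro group rather than exchanging it for trifluoromethyl, and it sits on an amide rather than a urea, so it bears on the present step only loosely; still, it shows that altering this ring position left the number essentially unchanged. Going by the values given here, no measured pair shows the chloro to trifluoromethyl exchange itself. He therefore expects a 1.0-fold lower number from compound 1 to compound 4 (0.00 log units; within the scatter), a step that does not go beyond the scatter in either direction. For compound 4 in this assay he estimates 1900 nM, in a range from 900 nM to 4200 nM.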

Compound 4, concentration for total growth inhibition: 1460 nM
For compound 4 the middle estimate is 1.3-fold (0.11 log units) above the measured one; measured number inside the range.
By their numbers in this assay, from the lowest: compounds 4, 1, 3 and 2 (each within the scatter of the next, the first and the last beyond it).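

The earlier compounds shown here held no pair with this exchange, and in this assay the step of trifluoromethyl in place of chloro on the urea aryl now reads as a 1.3-fold lower number from compound 1 to compound 4 (0.12 log units; within the scatter) at an aromatic carbon ortho to a chloro group and meta to a large group. At this position, then, a group of four heavy atoms stands in place of a group of one heavy atom, and the 3,4-dichlorophenyl and 4-chloro-3-(trifluoromethyl)phenyl compounds cannot be told apart in this assay. For the compounds shown here, the only other step on this aryl ring, a 1.0-fold lower number from compound 2 to compound 3 (0.02 log units; within the scatter), removes a chloro group on an amide, so the two steps are different changes, and both stay within the scatter.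

The compounds shown leave open whether an amine, a carboxylic acid or a longer chain at this position would move the number beyond the scatter, and whether the same exchange would read alike on the amide series of compound 2 and compound 3. No measurement at hand offers any account of why these two groups read alike.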